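The source may report more compounds than this note shows. Statements on the series, on what has been measured and on what is new or still open speak of the compounds shown alone.

Measured compounds:
compound 1 `CC(C)c1nc(C(=O)NCC2CCN(C3CCC3)CC2)c2ccccn12`: 20%
compound 2 `CC(C)c1nc(C(=O)NC[C@@H]2[C@H]3CN(CC4CCC4)C[C@@H]23)c2ccccn12`: 50%

Of the compounds shown here, two have been measured in a functional assay on CHO cells for agonist activity at 5-hydroxytryptamine receptor 4 (Homo sapiens), read by a luciferase reporter and cAMP accumulation, with a stated time of 4 h; on this read-out higher numbers stand for larger maximal responses and lower numbers for smaller maximal responses. Compound 1 `CC(C)c1nc(C(=O)NCC2CCN(C3CCC3)CC2)c2ccccn12` gives 20% in this assay. Compound 2 `CC(C)c1nc(C(=O)NC[C@@H]2[C@H]3CN(CC4CCC4)C[C@@H]23)c2ccccn12` gives 50% in this assay, the higher of the two numbers shown, and the gap between compound 2 and compound 1 lies beyond the usual scatter of this measurement. The two compounds differ in more than one place, so nothing in the data ties this gap to a single change.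

The next compound is compound 3 `CC(C)c1nc(C(=O)NC[C@@H]2[C@H]3CN(C4CCC4)C[C@@H]23)c2ccccn12`, which has not yet been measured in this assay. It differs from compound 2 in one place: cyclobutyl in place of cyclobutylmethyl on an amine nitrogen in a ring. The ring on the amine nitrogen is kept and only the linking carbon is removed. Within the data shown here, no measured pair shows the effect of this change on the bicyclic amine. The step of a number 10 percentage points lower from compound 2 to compound 3 (within the scatter) is therefore expected to be small, with a slight lean downward, and it may well fall within the scatter. Compound 3 is expected to reach about 40%, in a range from 15% to 65%.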

Compound 3, largest response reached (Emax), in percent of the reference or control that the assay uses: 59%
Compound 3: the middle estimate sits 19 percentage points below what was measured; low and high end bracket the measured number.
By their numbers in this assay, from the lowest: compound 1; then compounds 2 and 3 (each within the scatter of the next).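

In this assay, among these compounds, exchanging cyclobutylmethyl for cyclobutyl on an amine nitrogen in a ring of the fused or bridged system gives a number 9 percentage points higher from compound 2 to compound 3 (within the scatter), the first step in this set that isolates a single place. The linking carbon can therefore be removed from this nitrogen, with the four-membered carbon ring kept, without a shift that can be told from the scatter, so compound 2 and compound 3 cannot be ranked against each other on this read-out. No measurement shown here accounts for the two groups reading alike.

The compounds shown leave open whether other groups on the same nitrogen, such as cyclopropyl, cyclopentyl, cyclobutylethyl or an open chain such as isopropyl, would read like these two or would move the maximal response beyond the scatter. Going by these compounds, it also stays open whether cyclobutylmethyl and cyclobutyl would read alike on the amine nitrogen of compound 1, so this one step cannot be carried over to that core.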